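From ethoxycarbonyl to (benzyloxycarbonyl)methyl in a level series

The source may hold more compounds than are shown below. What is called first, only, known or untested is meant among the compounds shown, and "the series" means these compounds.

In a functional assay on A-427 cells (Homo sapiens) for cytotoxicity, read by colorimetric assay and MTT assay (on this read-out lower numbers stand for stronger inhibition and higher numbers for weaker inhibition), compound 1 `COc1cccc2cc(-c3ccccc3)c(O)nc12` gives 10000 nM and compound 2 `COc1ccc(-c2cc3c(OC)ccc(OC)c3nc2O)cc1` gives 10000 nM as well. Compound 3 `CCOC(=O)Cn1c(=O)c(-c2ccc(OC)cc2)cc2c(OC)cc(OC)cc21` gives 10000 nM and so stands level with both. From the compounds shown here alone, compound 4 `COc1ccc(-c2cc3c(OC)cc(OC)cc3n(CCC(=O)OCc3ccccc3)c2=O)cc1` is still untested. The change from compound 3 is (benzyloxycarbonyl)methyl in place of ethoxycarbonyl on a saturated chain carbon bound to an aromatic nitrogen and amounts to (benzyloxycarbonyl)methyl in place of ethoxycarbonyl on a saturated chain carbon bound to an aromatic nitrogen. For the measured compounds named here, no two measured compounds differ in one place only, so no single change has a known size here. The three measured values show no spread, so only a small step towards stronger inhibition is expected in this assay and it may stay within the scatter. The estimate means a 1.3-fold lower number from compound 3 to compound 4 (0.10 log units; within the scatter) as the expected outcome. The estimate for compound 4 is 8000 nM with an expected range from 3000 nM to 12000 nM in repeat measurements.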

Compound 4, half-maximal inhibitory concentration: 10000 nM
For compound 4 the middle estimate is 1.3-fold (0.10 log units) below the measured one, and the stated range covers the measured number.
By their numbers in this assay, from the lowest: compounds 1, 2, 3 and 4 (each within the scatter of the next).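

In this assay, for the compounds shown here, the first comparison that differs in one place only gives no change at the digits printed from compound 3 to compound 4 (within the scatter) for (benzyloxycarbonyl)methyl in place of ethoxycarbonyl. So, on a saturated chain carbon bound to an aromatic nitrogen, the larger group with its six-membered aromatic ring of carbon only leaves the read-out level. Nothing available explains this result.

From the compounds shown here alone, whether a carboxylic acid or an amine in this place would move the number stays open. The differences among compounds 1, 2 and 3 cannot be read as single steps.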